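Trifluoromethoxy for Trifluoromethyl in an Oral Rat Assay

This account rests on a few compounds, and the source may have more. Where it says the series, first, only, none or still open, it means among the compounds named here.

Compound 1 `Cc1noc(NC(=O)N2CCC3(CC2)CC(c2cccc(OC(F)(F)F)c2)C3)c1C` and compound 2 `Cn1nnnc1NC(=O)N1CCC2(CC1)CC(c1cccc(C(F)(F)F)c1)C2` share a core but differ in more than one place, so only their values stand side by side. In a functional assay on the whole organism for inhibition, with Rattus norvegicus as the target, with a stated time of 3 h, at a dose of 3 mg/kg by the oral route (a lower number here means that less compound is needed, a higher number that more compound is needed for the effect), compound 1 gives 1 mg/kg. In this assay compound 2 gives 1 mg/kg, level with compound 1 at the digits shown and within the scatter.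

Compound 3 `Cn1nnnc1NC(=O)N1CCC2(CC1)CC(c1cccc(OC(F)(F)F)c1)C2` has not yet been measured. It differs from compound 2 in a single place: trifluoromethoxy in place of trifluoromethyl on an aromatic carbon. Among the compounds with values here, no step between measured compounds isolates this change. What the numbers do show is that compound 1, carrying the trifluoromethoxy group, gives 1 mg/kg, while compound 2, carrying trifluoromethyl, gives 1 mg/kg, with no gap beyond the scatter. The expected step is therefore no change at the digits printed from compound 2 to compound 3 (within the scatter), in no direction beyond the scatter. Compound 3 is estimated at 1 mg/kg, with a range from 0.3 mg/kg to 3 mg/kg.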

Compound 3, minimum effective dose: 0.1 mg/kg
The estimate for compound 3 lay 10-fold (1.00 log units) above the measured number; the whole stated range lies above it.
By their numbers in this assay, from the lowest: compound 3; then compounds 1 and 2 (each within the scatter of the next).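

In this assay, trifluoromethoxy in place of trifluoromethyl on the aromatic carbon gives a 10-fold lower number from compound 2 to compound 3 (1.00 log units; beyond the scatter), so this position responds to this change, something the level values of compounds 1 and 2 could not show. With trifluoromethoxy held constant, 1-methyl-1H-tetrazol-5-yl in place of 3,4-dimethyl-1,2-oxazol-5-yl on the amide-type nitrogen gives a 10-fold lower number from compound 1 to compound 3 (1.00 log units; beyond the scatter), so that place responds as well. No measurement shown gives a reason for either step.

The compounds shown leave open whether trifluoromethoxy would give a similar step when paired with 3,4-dimethyl-1,2-oxazol-5-yl rather than 1-methyl-1H-tetrazol-5-yl. They also leave open how a methoxy group or a nitrile on the same aromatic carbon would compare with trifluoromethoxy.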